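A few compounds are considered here, and "the series" means these few. Any claim that something is new, unique, unknown or untested is made for them only; others in the source may bear on it.

Measured in a functional assay on A549 cells (Homo sapiens) for antiproliferative activity, read by MTT assay, with a stated time of 48 h; a higher number here means a weaker inhibitor, a lower number a stronger inhibitor:
- compound 1 `O=C(/C=C/c1ccc(C(F)(F)F)cc1)Nc1nnc(-c2ccc(Br)cc2)s1`: 4.68 ug/mL
- compound 2 `COc1ccc(-c2nnc(NC(=O)/C=C/c3ccc(C)cc3)s2)cc1`: 0.58 ug/mL
- compound 3 `COc1ccc(-c2nnc(NC(=O)/C=C/c3ccc(F)cc3)s2)cc1`: 0.75 ug/mL

Compound 3 gives 0.75 ug/mL, level with compound 2 within the scatter and well under compound 1, a gap beyond the scatter.

Next is compound 4 `O=C(/C=C/c1ccc(F)cc1)Nc1nnc(-c2ccc(Br)cc2)s1`, which keeps the fluoro of compound 3. The change is bromo in place of methoxy on an aromatic carbon, para to a large group, or 4-methoxyphenyl to 4-bromophenyl.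

For the measured compounds named here, the one measured step, a 1.3-fold higher number from compound 2 to compound 3 (0.11 log units; within the scatter), is fluoro in place of methyl. It concerns a different place and gives no size for this change. Going by the values given here, no measured pair isolates methoxy against bromo.

Among the compounds with values here, the only pointer is compound 1, which carries the 4-bromophenyl and stands at 4.68 ug/mL. It also has trifluoromethyl where compound 3 has fluoro, so its gap cannot be assigned to the bromo alone.

A move to a higher number is therefore expected in this assay, covering only part of that gap, with an estimated size of a 2.7-fold higher number from compound 3 to compound 4 (0.43 log units; beyond the scatter). The evidence is thin, so the range is wide. For compound 4 the estimate is 2 ug/mL, with an expected range of 0.7 ug/mL to 6 ug/mL.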

Compound 4, half-maximal inhibitory concentration: 2.83 ug/mL
For compound 4 the middle estimate is 1.4-fold (0.15 log units) below the measured one; the range from low to high includes it.
By their numbers in this assay, from the lowest: compounds 2 and 3 (each within the scatter of the next); then compounds 4 and 1 (each within the scatter of the next).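

In this assay, the change from 4-methoxyphenyl to 4-bromophenyl, with the fluoro held fixed, now has a measured size of its own: a 3.8-fold higher number from compound 3 to compound 4 (0.58 log units; beyond the scatter) and so a loss of activity at this position on the fluoro background. For the compounds shown here, the same 4-bromophenyl background also gives the first direct comparison of the two groups at the other end of the molecule, a 1.7-fold lower number from compound 1 to compound 4 (0.22 log units; within the scatter) for fluoro in place of trifluoromethyl, so only the methoxy-to-bromo step lies beyond the scatter and fluoro and trifluoromethyl are not separated here. No measurement at hand gives a reason for either step.

As far as these compounds go, each step rests on a single pair, so it remains open whether the methoxy-to-bromo step keeps its size with methyl or trifluoromethyl in place of the fluoro. Also open, from the compounds shown here alone, is how an amine or a carboxylic acid would read at this same place on the aromatic ring, para to a large group, against methoxy and bromo.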